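Swapping an oxazole for an isoxazole: expected permeability

The source may report more compounds than this note shows. Statements on the series, on what has been measured and on what is new or still open speak of the compounds shown alone.

Compound 1, `Cc1ccc(NS(=O)(=O)c2cccc(C(=O)NCc3nc(C)no3)c2)cc1`: 22 10^-6 cm/s
Compound 2, `Cc1noc(CNC(=O)c2ccc(C)c(S(=O)(=O)Nc3ccc(-c4cnco4)cc3)c2)n1`: 10 10^-6 cm/s
Compound 3, `COc1ccc(C(=O)NCc2nc(C)no2)cc1S(=O)(=O)Nc1ccc(C)cc1`: 8 10^-6 cm/s

In an ADME assay on MDCK-II cells (Canis lupus familiaris) for permeability (on this read-out higher numbers stand for higher permeability and lower numbers for lower permeability), compound 2 gives 10 10^-6 cm/s, the second highest of the three numbers; compound 3 lies within the scatter of it, while compound 1 sits higher by a step beyond the scatter. Compound 4, `Cc1noc(CNC(=O)c2ccc(C)c(S(=O)(=O)Nc3ccc(-c4ccno4)cc3)c2)n1`, differs from compound 2 by 1,2-oxazol-5-yl in place of 1,3-oxazol-5-yl on an aromatic carbon. Going by the values given here, the only measured single change, a 2.8-fold lower number from compound 1 to compound 3 (0.44 log units; beyond the scatter), concerns a different group at a different place, so no measured step bears directly on this swap. The two rings hold the same atoms joined differently, so the expected step is no change at the digits printed from compound 2 to compound 4 (within the scatter), nothing beyond the scatter. For compound 4 the estimate in this assay is 10 10^-6 cm/s, with a range from 5 10^-6 cm/s to 20 10^-6 cm/s.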

Compound 4, apparent permeability: 6 10^-6 cm/s
Compound 4: middle estimate off by 1.7-fold (0.22 log units), on the high side; the measured number falls inside the stated range.
By their numbers in this assay, from the lowest: compounds 4, 3 and 2 (each within the scatter of the next); then compound 1.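

Going by these compounds alone, this is the first step measured at this position, on an aromatic carbon para to a large group. In this assay, 1,2-oxazol-5-yl in place of 1,3-oxazol-5-yl gives a 1.7-fold lower number from compound 2 to compound 4 (0.22 log units; within the scatter), so rejoining the same ring atoms leaves the result within the usual scatter here. No supporting measurement bears on this small difference.

Still open, going by these compounds, is how this assay responds when a different kind of group, such as an amine or a carboxylic acid, stands at this position. On these data alone, whether this swap behaves alike on the core of compound 3 also remains open.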